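A few compounds are considered here, and "the series" means these few. Any claim that something is new, unique, unknown or untested is made for them only; others in the source may bear on it.

Measured so far:
Compound 1, `Cc1noc(-c2nc(C)c3c(c2N)C(=O)N(Cc2ccc(Br)cc2)C3=O)n1`, in a physicochemical assay for solubility, using the shake flask method, in simulated intestinal fluid, measured as kinetic solubility, with a stated time of 2 h, at 25 degrees C, at pH 6.5 (a lower number here means a less soluble compound, a higher number a more soluble compound), gives < 5000 nM, which is a limit of the assay rather than a number.
Compound 2, `Cc1noc(-c2nc(C)c3c(c2N)C(=O)N(Cc2ccc(C#N)cc2)C3=O)n1`, in this assay gives < 5000 nM, likewise a limit of the assay and not a number.

Compound 2 therefore stands at the reporting limit, the point at which both shown values sit (the limit of < 5000 nM in this assay, at which 2 of the 2 values shown sit). Within the data shown here, the single measured step, a step that the two limits leave unreadable from compound 1 to compound 2, runs between two limits, so its size cannot be read. Compound 3, `Cc1noc(-c2nc(C)c3c(c2N)C(=O)N(Cc2ccc(N4CCCC4=O)cc2)C3=O)n1`, differs from compound 2 by 2-oxopyrrolidin-1-yl in place of cyano on an aromatic carbon. Among the measured compounds shown here, no measured step of readable size bears on this change, so the data give no direction beyond the scatter to carry forward. The estimate for compound 3 in this assay is 6000 nM, within a range from 1500 nM to 25000 nM. The step this estimate implies, an at least 1.2-fold higher number from compound 2 to compound 3 (0.07 log units; that floor lies within the scatter), is expected to be modest and uncertain, with a real chance that compound 3 again returns only a limit.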

Compound 3, solubility: < 5000 nM
Compound 3: a limit, no number; the forecaster's own chance of this, stated with the estimate: 45%; middle value at least 1.2-fold (0.07 log units) from the limit.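

Compound 1, compound 2 and compound 3 all return only a limit of the assay, so no step among them can be read: the limit of < 5000 nM in this assay, at which 3 of the 3 values shown sit.

The compounds shown leave open whether bromo, cyano and 2-oxopyrrolidin-1-yl on the aromatic carbon differ at all in this assay.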